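This account rests on a few compounds, and the source may have more. Where it says the series, first, only, none or still open, it means among the compounds named here.

Of the compounds shown here, two have so far been measured in a functional assay on the whole organism for inhibition, with Brassica rapa subsp. chinensis as the target, with a stated time of 3 days, tested at 100 ppm; a lower number here means less inhibition of growth, a higher number more inhibition of growth at the concentration tested. Compound 1 `CCCOC(=O)/C=C/c1ccc(C(C)C)cc1` gives 8% in this assay, and compound 2 `CCCNC(=O)/C=C/c1ccccc1` gives 15%. On the numbers shown compound 2 stands alongside compound 1, with a gap that lies within the scatter, so the two cannot be told apart and both show only weak inhibition of growth. Compound 3 `CCCOC(=O)/C=C/c1ccccc1` has not yet been measured. It differs from compound 2 in one place: propoxy in place of propylamino on a carbonyl carbon. Compound 1 also carries a propoxy group on its carbonyl carbon, and its reading of 8% sits close to that of compound 2. On that basis compound 3 is expected to remain in the same weak region, and the expected step of a number 5 percentage points lower from compound 2 to compound 3 (within the scatter) is none beyond the scatter. Compound 3 is estimated at 10%, with a range from 0% to 25%.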

Compound 3, percent growth inhibition at one concentration: 31%
For compound 3 the middle estimate is 21 percentage points below the measured one, and the stated range ends below it.
By their numbers in this assay, from the lowest: compounds 1 and 2 (each within the scatter of the next); then compound 3.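

In this assay the group on the carbonyl carbon proves to matter: propoxy in place of propylamino gives a number 16 percentage points higher from compound 2 to compound 3 (beyond the scatter) and so moves the reading beyond the scatter, although both groups have the same number of heavy atoms and differ in one atom, oxygen for nitrogen, which removes a hydrogen-bond donor and adds an acceptor. The aromatic ring matters as well: hydrogen in place of isopropyl on an aromatic carbon gives a number 23 percentage points higher from compound 1 to compound 3 (beyond the scatter) and shows that, with propoxy held constant, the isopropyl compound reads lower. No measurement at hand explains either step.

Going by these compounds, each step rests on a single pair at one concentration, so it remains open whether a longer chain or a carboxylic acid on the carbonyl carbon would keep this level of inhibition. On these data alone, it is equally open how a chlorine or a methoxy group on the aromatic carbon would compare with hydrogen and isopropyl.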